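Cyclohexyl for 2-fluorobenzyl at the piperidine nitrogen

The source may report more compounds than this note shows. Statements on the series, on what has been measured and on what is new or still open speak of the compounds shown alone.

Compound 1 `Cc1ccc2c(NCc3ccc(NC(=O)C4CCN(Cc5ccccc5)CC4)cc3)nc(N3CCN[C@@H](C)C3)nc2c1` in a functional assay on SV5A8 cells (Homo sapiens) for cytotoxicity (a higher number here means a weaker inhibitor, a lower number a stronger inhibitor), gives > 8860 nM, a limit of the assay.
Compound 2 `Cc1ccc2c(NCc3ccc(NC(=O)C4CCN(Cc5ccccc5F)CC4)cc3)nc(N(C)C)nc2c1` in this assay gives > 6670 nM, also a limit.
Compound 3 `Cc1ccc2c(NCc3ccc(NC(=O)C4CCN(Cc5ccccc5)CC4)cc3)nc(N(C)CCCN(C)C)nc2c1` in this assay gives > 8620 nM, again a limit.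

Compound 2 thus stands only at a limit, and the two further values shown are limits as well, so no ordering among the three measured compounds can be read. Among the compounds with values here, the one measured single-point change, a step that the two limits leave unreadable from compound 1 to compound 3, is unreadable for the same reason and does not touch the part of the structure changed here.

Compound 4 `Cc1ccc2c(NCc3ccc(NC(=O)C4CCN(C5CCCCC5)CC4)cc3)nc(N(C)C)nc2c1` differs from compound 2 by cyclohexyl in place of 2-fluorobenzyl on an amine nitrogen in a ring. Within the data shown here, no measured step bears directly on this exchange; what the series shows is only that every measured compound sits at a limit (the limit of > 6670 nM in this assay, at which 1 of the 3 values shown sits, (the limit of > 8620 nM in this assay, at which 1 of the 3 values shown sits), (the limit of > 8860 nM in this assay, at which 1 of the 3 values shown sits)). On that basis no step beyond the scatter is expected in this assay, and compound 4 is estimated at 8000 nM, with a range from 3000 nM to 25000 nM. The expected step that the limit leaves unreadable from compound 2 to compound 4 is therefore essentially none, with a limit the most likely outcome.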

Compound 4, half-maximal inhibitory concentration: > 8320 nM
Compound 4: no number, only a limit; the forecaster's own chance of this, stated with the estimate: 85%; middle value at least 1.0-fold (0.01 log units) away from the limit.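

In this assay compound 4 gives > 8320 nM, a limit. Within the data shown here, compound 2 gives > 6670 nM, also a limit, so no step between compound 2 and compound 4 can be read. The compounds shown leave open whether exchanging 2-fluorobenzyl for cyclohexyl on the amine nitrogen in a ring changes the value at all.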